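The source may hold more compounds than are shown below. What is called first, only, known or untested is meant among the compounds shown, and "the series" means these compounds.

Measured so far in a functional assay on HBL-100 cells (Homo sapiens) for inhibition, read by sulforhodamine B assay, with a stated time of 48 h; on this read-out lower numbers stand for stronger inhibition of growth and higher numbers for weaker inhibition of growth:
compound 1 `O=C(/C=C/C1CCCCC1)c1ccccc1` — 18000 nM
compound 2 `O=C(/C(=C/c1ccccc1)CCl)c1ccccc1` — 12000 nM
compound 3 `O=C(/C(=C/c1ccc(Cl)cc1)CCl)c1ccccc1` — 3200 nM

Compound 3 stands lowest of the three numbers in this assay. Its nearest neighbour is compound 2, the step being a 3.8-fold lower number from compound 2 to compound 3 (0.57 log units; beyond the scatter); compound 1 lies furthest away, and its value against that of compound 3 shows a wider gap.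

Compound 4 `O=C(/C(=C/c1ccc(Cl)cc1Cl)CCl)c1ccccc1` is not yet measured. The change from compound 3 is chloro in place of hydrogen on an aromatic carbon. Within the data shown here, the only measured step that bears on it is the one from compound 2 to compound 3, which was also a chloro in place of hydrogen on an aromatic carbon and gave a 3.8-fold lower number from compound 2 to compound 3 (0.57 log units; beyond the scatter). A second chloro on the same ring is expected to move the number in the same direction, though the step is not expected to be larger than the first one, so a modest step beyond the scatter, a 1.8-fold lower number from compound 3 to compound 4 (0.25 log units; within the scatter), is the expectation. On that basis compound 4 is estimated at 1800 nM, with a range from 600 nM to 5000 nM.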

Compound 4, concentration for 50% growth inhibition: 3100 nM
Beside the measured number, compound 4's estimate is 1.7-fold (0.24 log units) below it; measured number inside the range.
By their numbers in this assay, from the lowest: compounds 4 and 3 (each within the scatter of the next); then compounds 2 and 1 (each within the scatter of the next).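

In this assay, chloro in place of hydrogen on an aromatic carbon, here ortho to a large group and meta to a chloro group, gives a 1.0-fold lower number from compound 3 to compound 4 (0.01 log units; within the scatter). The same kind of replacement earlier gave a 3.8-fold lower number from compound 2 to compound 3 (0.57 log units; beyond the scatter), so across these two steps the change does not carry a step of the same size at each place, and the step beyond the scatter does not recur at this position. Nothing available explains this difference between the two steps.

On these data alone, whether a methoxy group, an amine or a carboxylic acid at this same place would also stay within the scatter of compound 3 remains open. Also open, as far as these compounds go, is how chloro at this place would read without the chloro group it is meta to.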